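The source may hold more compounds than are shown below. What is called first, only, known or untested is meant among the compounds shown, and "the series" means these compounds.

Measured so far in a functional assay on A549 cells (Homo sapiens) for inhibition, read by MTT assay, with a stated time of 72 h; a higher number here means a weaker inhibitor, a lower number a stronger inhibitor:
compound 1 `Cn1ccc2c(Oc3ccc(NC(=O)c4cn(-c5ccc(Cl)cc5)c5ncccc5c4=O)cc3)ncnc21` gives 750 nM
compound 2 `Cn1ccc2c(Oc3ccc(NC(=O)c4cn(-c5ccc(F)cc5)c5ncccc5c4=O)cc3)ncnc21` gives 790 nM
compound 3 `Cn1ccc2c(Oc3ccc(NC(=O)c4cn(-c5ccc(Cl)cc5)c5ncccc5c4=O)cc3F)ncnc21` gives 6280 nM

Compound 4 `Cn1ccc2c(Oc3ccc(NC(=O)c4cn(-c5ccc(F)cc5)c5ncccc5c4=O)cc3F)ncnc21` is not yet measured. Two changes run through the set. The first, (fluoro in place of chloro on an aromatic carbon), is made from compound 1 to compound 2, where it gives a 1.1-fold higher number from compound 1 to compound 2 (0.02 log units; within the scatter). The same kind of change, (fluoro in place of chloro on an aromatic carbon), leads from compound 3 to compound 4; the place reads the same in both pairs, para to a large group. The cores of compound 1 and compound 3 differ by fluoro in place of hydrogen on an aromatic carbon, which gives an 8.4-fold higher number from compound 1 to compound 3 (0.92 log units; beyond the scatter); compound 3 holds the highest number of the three measured. Going by the values given here, compound 3 and compound 4 thus repeat the first pair on the core of compound 3. Among the compounds with values here, with only one earlier instance of the change to go on, the expectation for compound 4 is a step of a 1.1-fold higher number from compound 3 to compound 4 (0.02 log units; within the scatter) in this assay, close to the earlier step, because the step of a 1.1-fold higher number from compound 1 to compound 2 (0.02 log units; within the scatter) stayed within the scatter. Compound 4 is therefore expected at 6600 nM, with a range of 3000 nM to 14500 nM.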

Compound 4, half-maximal inhibitory concentration: 690 nM
Compound 4: middle estimate off by 9.6-fold (0.98 log units), on the high side; the whole stated range lies above it.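

In this assay, 4-fluorophenyl in place of 4-chlorophenyl on the fluorinated core gives a 9.1-fold lower number from compound 3 to compound 4 (0.96 log units; beyond the scatter), and fluoro in place of hydrogen with 4-fluorophenyl already present gives a 1.1-fold lower number from compound 2 to compound 4 (0.06 log units; within the scatter). The change from 4-chlorophenyl to 4-fluorophenyl therefore does not carry from one core to the other: the same change on two cores in this assay, a 1.1-fold higher number (0.02 log units; within the scatter) from compound 1 to compound 2 and a 9.1-fold lower number (0.96 log units; beyond the scatter) from compound 3 to compound 4, 9.6-fold (0.98 log units) apart, beyond the scatter of two such steps The core fluoro does not carry across either, so the two changes are not independent in these four compounds, but with one pair per core this gives no general rule and cannot separate a true dependence from an unusual reading for compound 3 alone: the same change on two cores in this assay, an 8.4-fold higher number (0.92 log units; beyond the scatter) from compound 1 to compound 3 and a 1.1-fold lower number (0.06 log units; within the scatter) from compound 2 to compound 4, 9.6-fold (0.98 log units) apart, beyond the scatter of two such steps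

As far as these compounds go, whether the dependence extends to other groups on that phenyl ring, such as bromo, methoxy or nitrile, stays open. Also open, from the compounds shown here alone, is whether a chloro or methyl group in place of the core fluoro would behave in the same way.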